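The source may hold more compounds than are shown below. What is called first, only, known or untested is meant among the compounds shown, and "the series" means these compounds.

Compound 1 `COc1ccc(C2C(C#N)=C(/N=C/c3ccccc3)Oc3nc(Nc4ccc(S(N)(=O)=O)cc4)sc32)cc1` gives 33600 nM in a functional assay on MCF7 cells (Homo sapiens) for cytotoxicity, read by sulforhodamine B assay, with a stated time of 48 h; a higher number here means a weaker inhibitor, a lower number a stronger inhibitor. Within the data shown here, compound 2 `COc1ccc(C2C(C#N)=C(/N=C/c3cccc(Br)c3)Oc3nc(Nc4ccc(S(N)(=O)=O)cc4)sc32)cc1` gives 9390 nM in this assay, the lowest of the two numbers so far; the single measured step, a 3.6-fold lower number from compound 1 to compound 2 (0.55 log units; beyond the scatter), separates it from compound 1. Compound 3 `COc1ccc(C2C(C#N)=C(/N=C/c3ccc(F)cc3)Oc3nc(Nc4ccc(S(N)(=O)=O)cc4)sc32)cc1` differs from compound 2 by 4-fluorophenyl in place of 3-bromophenyl on a carbon with a double bond to nitrogen. Among the measured compounds shown here, no measured step covers this exchange directly: the step of a 3.6-fold lower number from compound 1 to compound 2 (0.55 log units; beyond the scatter) shows only that taking the bromine away moves the number up, and the fluorine has no precedent. The expected step is therefore a 2.1-fold higher number from compound 2 to compound 3 (0.33 log units; beyond the scatter), upward but modest. Compound 3 is estimated at 20000 nM in this assay, with a range from 8000 nM to 50000 nM.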

Compound 3, half-maximal inhibitory concentration: 28900 nM
For compound 3 the middle estimate is 1.4-fold (0.16 log units) below the measured one; low and high end bracket the measured number.
By their numbers in this assay, from the lowest: compound 2; then compounds 3 and 1 (each within the scatter of the next).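

On the carbon with a double bond to nitrogen, 4-fluorophenyl does not hold what 3-bromophenyl gave: a 3.1-fold higher number from compound 2 to compound 3 (0.49 log units; beyond the scatter). Set against the plain phenyl, the fluorine makes no readable difference, a 1.2-fold lower number from compound 1 to compound 3 (0.07 log units; within the scatter), so among these three compounds the gain rests on compound 2 alone. No evidence on the cause of these results is at hand.

The exchange alters the halogen and its ring position together, leaving 4-bromophenyl and 3-fluorophenyl as the groups that would separate the two. On these data alone, whether an amine or a carboxylic acid on this phenyl ring would move the number also stays open.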